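Sulfonyl aryl variation in the 5-HT6 agonist series

The compounds below may be only part of what the source reports. "The series", "measured", "known", "first", "only" and "open" are said of these compounds alone.

Compound 1 `CN1CCCC(n2cc(S(=O)(=O)c3cccc(C(F)(F)F)c3)c3cccnc32)C1`, compound 2 `CN1CCCC(n2cc(S(=O)(=O)c3cccc(F)c3)c3cccnc32)C1` and compound 3 `CC(C)N1CCCC(n2cc(S(=O)(=O)c3cccc(F)c3)c3cccnc32)C1` share one core and differ at the sulfonyl aryl group or at the amine nitrogen in the ring. In a functional assay on HeLa cells for agonist activity at 5-hydroxytryptamine receptor 6 (Homo sapiens), read by cAMP accumulation and immunoassay (on this read-out lower numbers stand for an effect already at smaller amounts and higher numbers for an effect only at larger amounts of compound), compound 1 gives 49 nM, compound 2 gives 306 nM and compound 3 gives 172 nM. Compound 2 holds the highest of the three numbers; its nearest neighbour is compound 3, with a 1.8-fold lower number from compound 2 to compound 3 (0.25 log units; within the scatter), and its furthest is compound 1, with a 6.2-fold higher number from compound 1 to compound 2 (0.80 log units; beyond the scatter).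

Compound 4 `CN1CCCC(n2cc(S(=O)(=O)c3cc(Cl)cc(Cl)c3)c3cccnc32)C1` is the next member: 3,5-dichlorophenyl in place of 3-fluorophenyl on a sulfonyl sulfur. Among the compounds with values here, the only measured step at this ring is the one from compound 1 to compound 2, where a 6.2-fold higher number from compound 1 to compound 2 (0.80 log units; beyond the scatter) shows that the group on the sulfonyl phenyl moves the number well beyond the scatter. Within the data shown here, no measured step involves a dichlorophenyl, so the direction is taken from compound 1, whose larger substituent gave 49 nM. A lower number than compound 2 is therefore expected for compound 4, modest in size, a 3.4-fold lower number from compound 2 to compound 4 (0.53 log units; beyond the scatter). Compound 4 is estimated at 90 nM, in a range from 30 nM to 270 nM.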

Compound 4, half-maximal effective concentration: 38.7 nM
Beside the measured number, compound 4's estimate is 2.3-fold (0.37 log units) above it, within the range that was stated.
By their numbers in this assay, from the lowest: compounds 4 and 1 (each within the scatter of the next); then compounds 3 and 2 (each within the scatter of the next).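

In this assay, 3,5-dichlorophenyl in place of 3-fluorophenyl on the sulfonyl sulfur gives a 7.9-fold lower number from compound 2 to compound 4 (0.90 log units; beyond the scatter), so a second group at this position, besides the trifluoromethyl-bearing ring of compound 1, separates from compound 2 beyond the scatter. Compound 1 at 49 nM and compound 4 at 38.7 nM lie within the scatter of each other, so these two groups cannot be ordered in this assay. Nothing available explains the change in the number.

Open, as far as these compounds go, is how a sulfonyl phenyl carrying an amine, a carboxylic acid or a single chlorine would read. Also open, from the compounds shown here alone, is whether isopropyl on the ring amine nitrogen, as in compound 3, would keep the number of compound 4 when paired with 3,5-dichlorophenyl.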